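Fluoro on the distal phenyl of compound 1

A few compounds are considered here, and "the series" means these few. Any claim that something is new, unique, unknown or untested is made for them only; others in the source may bear on it.

Measured so far:
Compound 1 `COc1c(N2CC[C@@H](N)C2)c(F)cc2c(=O)c(C(=O)O)cn(Cc3ccc(-c4ccccc4)cc3)c12` gives 92200 nM in an assay on isolated protein for inhibition of DNA topoisomerase 1 (Homo sapiens), with a stated time of 15 min; a higher number here means a weaker inhibitor, a lower number a stronger inhibitor.
Compound 2 `CNCCCNc1c(F)cc2c(=O)c(C(=O)O)cn(Cc3ccc(-c4ccccc4)cc3)c2c1OC` gives 101000 nM.
Compound 3 `CNCCNc1c(F)cc2c(=O)c(C(=O)O)cn(Cc3ccc(-c4ccccc4)cc3)c2c1OC` gives > 200000 nM, which is a limit of the assay and not a number.

Compound 1 holds the lowest of the two numbers in hand, with compound 2 close by: a 1.1-fold higher number from compound 1 to compound 2 (0.04 log units; within the scatter). For the measured compounds named here, the step to compound 3 reads an at least 2.1-fold higher number from compound 1 to compound 3 (0.33 log units; beyond the scatter), and between the two open-chain amines it is an at least 1.9-fold higher number from compound 2 to compound 3 (0.29 log units; that floor lies within the scatter); compound 3 is the one value sitting at the limit of > 200000 nM in this assay, at which 1 of the 3 values shown sits.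

Compound 4 `COc1c(N2CC[C@@H](N)C2)c(F)cc2c(=O)c(C(=O)O)cn(Cc3ccc(-c4ccc(F)cc4)cc3)c12` differs from compound 1 by fluoro in place of hydrogen on an aromatic carbon. Going by the values given here, none of the measured steps bears on this part of the molecule: all three vary the amine-bearing group on the core, and the phenyl end is identical in compound 1, compound 2 and compound 3. The series therefore gives no measured change of a size to carry over, neither for a lower nor for a higher number. The working expectation is a step within the scatter, a 1.0-fold lower number from compound 1 to compound 4 (0.00 log units; within the scatter). Compound 4 is estimated at 92000 nM, with a range of 45000 nM to 185000 nM.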

Compound 4, half-maximal inhibitory concentration: 58600 nM
The estimate for compound 4 lay 1.6-fold (0.20 log units) above the measured number; low and high end bracket the measured number.
By their numbers in this assay, from the lowest: compounds 4, 1 and 2 (each within the scatter of the next). At a limit, above all of these: compound 3.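

For the compounds shown here, compound 4 is the first change at the phenyl end of the series, away from the amine-bearing group on the core that compound 2 and compound 3 vary. In this assay, phenyl to 4-fluorophenyl gives a 1.6-fold lower number from compound 1 to compound 4 (0.20 log units; within the scatter), so this ring carries a fluoro para to a large group with no step beyond the scatter, and the two values cannot be told apart. Going by these compounds alone, the change of one hydrogen for one fluoro therefore gives a first reading at this end of the molecule, but nothing measured here bears on the size of this step or offers a reason for it.

Still open, on these data alone, is whether a larger group in the same place, such as chloro, methoxy or trifluoromethyl, or a fluoro on another carbon of that ring, would give a step beyond the scatter. Also open, as far as these compounds go, is whether 4-fluorophenyl gives a comparable step with the open-chain amines of compound 2 and compound 3, or with an amide in place of the carboxylic acid on the core.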